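Swapping Chloro for Cyano on a Benzyl Ether Side Chain

This account rests on a few compounds, and the source may have more. Where it says the series, first, only, none or still open, it means among the compounds named here.

Compound 1 `O=c1c(OCc2ccccc2Cl)c(-c2ccccc2)oc2cc(O)cc(O)c12`: > 100000 nM in an ADME assay on Huh-5-2 cells (Homo sapiens) for cytotoxicity, read by WST assay, with a stated time of 3 days (on this read-out higher numbers stand for lower toxicity in this test and lower numbers for higher toxicity in this test), a limit of the assay.
Compound 2 `O=c1c(OCc2cccc(Cl)c2)c(-c2ccccc2)oc2cc(O)cc(O)c12`: 46000 nM in this assay.

Compound 2 holds the only number shown; compound 1 sits at the limit of > 100000 nM in this assay, at which 1 of the 2 values shown sits. Among the compounds with values here, the single measured step, an at least 2.1-fold lower number from compound 1 to compound 2 (0.33 log units; beyond the scatter), moves the chloro group rather than replacing it, so it bears only loosely on the change here. Compound 3 `N#Cc1cccc(COc2c(-c3ccccc3)oc3cc(O)cc(O)c3c2=O)c1` differs from compound 2 by cyano in place of chloro on an aromatic carbon. Within the data shown here, with no measured step for this swap, no shift beyond the scatter is expected. Compound 3 is estimated at 46000 nM, spanning 20000 nM to 100000 nM. That estimate means no change at the digits printed from compound 2 to compound 3 (within the scatter).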

Compound 3, half-maximal cytotoxic concentration: 21000 nM
Estimate against measurement, compound 3: 2.2-fold (0.34 log units) above, within the range that was stated.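

In this assay, cyano in place of chloro gives a 2.2-fold lower number from compound 2 to compound 3 (0.34 log units; beyond the scatter), so the group on this aromatic carbon affects the read-out, modestly and toward higher toxicity in this test. The 3-cyanophenyl group in place of 2-chlorophenyl gives an at least 4.7-fold lower number from compound 1 to compound 3 (0.67 log units; beyond the scatter). Compound 1 stands at a limit of the assay, so this step has no known upper end: the limit of > 100000 nM in this assay, at which 1 of the 3 values shown sits.

From the compounds shown here alone, how an amine or a carboxylic acid on this aromatic carbon would read remains open. The compounds shown also give no cause for the step from chloro to cyano.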